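From Carbamoyl to Chloro in a Urea Series

The compounds below may be only part of what the source reports. "The series", "measured", "known", "first", "only" and "open" are said of these compounds alone.

Three compounds sharing one urea core have been measured in a physicochemical assay for solubility, at pH 7.4; on this read-out lower numbers stand for lower solubility and higher numbers for higher solubility:

compound 1, `Cc1cc(NC(=O)Nc2cccc(F)c2)c2ccccc2n1`, gives 100 nM
compound 2, `COC(=O)c1ccc(NC(=O)Nc2cc(C)nc3ccccc23)cc1`, gives 1200 nM
compound 3, `Cc1cc(NC(=O)Nc2ccc(C(N)=O)cc2)c2ccccc2n1`, gives 900 nM

Compound 3 stands second highest of the three numbers. Its nearest neighbour is compound 2, which lies within the scatter of it; its furthest is compound 1, which lies beyond the scatter below it. Compound 4, `Cc1cc(NC(=O)Nc2ccc(Cl)cc2)c2ccccc2n1`, has not yet been measured in this assay. It differs from compound 3 in one place: chloro in place of carbamoyl on an aromatic carbon. For the measured compounds named here, the only step measured so far, a 1.3-fold lower number from compound 2 to compound 3 (0.12 log units; within the scatter), concerns a change on a carbonyl carbon and sits within the scatter, so it says little about exchanging a carbamoyl for a chloro on an aromatic ring. Going by the values given here, compound 1, which carries a fluoro on that ring, gives a number beyond the scatter below compound 3, which carries the carbamoyl; these two values are the only guide, though a fluoro is not a chloro and no single step links them. On that basis compound 4 is expected to show a lower number than compound 3, a step of about a 6.0-fold lower number from compound 3 to compound 4 (0.78 log units; beyond the scatter). The estimate for compound 4 in this assay is 150 nM, with a range from 50 nM to 450 nM.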

Compound 4, solubility: 1400 nM
Compound 4: middle estimate off by 9.3-fold (0.97 log units), on the low side; the measured number lies above the stated range.
By their numbers in this assay, from the lowest: compound 1; then compounds 3, 2 and 4 (each within the scatter of the next).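

In this assay, the aromatic carbon para to a large group tolerates very different groups without leaving the scatter: chloro in place of carbamoyl gives (a 1.6-fold higher number from compound 3 to compound 4 (0.19 log units; within the scatter)) and chloro in place of methoxycarbonyl gives (a 1.2-fold higher number from compound 2 to compound 4 (0.07 log units; within the scatter)), so the hydrogen-bond donor and acceptor counted on the carbamoyl can leave with no step beyond the scatter. For the compounds shown here, the only step beyond the scatter among the new ones is (a 14-fold higher number from compound 1 to compound 4 (1.15 log units; beyond the scatter)), with 4-chlorophenyl in place of 3-fluorophenyl on an amide-type nitrogen, which sets compound 1 apart from the other three compounds and shows that a halogen on this ring does not by itself go with a low number. The data at hand offer no measurement that accounts for either finding.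

Going by these compounds, what an amine, a carboxylic acid or a longer chain on that aromatic carbon would give remains open. Also open is whether the gap to compound 1 follows the fluoro against the chloro or the place of the halogen on the ring, as the compounds shown include neither a 4-fluorophenyl nor a 3-chlorophenyl on that nitrogen.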